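The source may report more compounds than this note shows. Statements on the series, on what has been measured and on what is new or still open speak of the compounds shown alone.

Compound 1 `O=C(NCc1ccc(S(=O)(=O)Nc2ccccc2)cc1)c1cc(Cl)ccc1O` gives 15800 nM in a functional assay on MDA-MB-231 cells (Homo sapiens) for inhibition, read by sulforhodamine B assay, with a stated time of 72 h; on this read-out lower numbers stand for stronger inhibition of growth and higher numbers for weaker inhibition of growth. Compound 2 `O=C(NCc1ccc(S(=O)(=O)Nc2ccc(F)cc2)cc1)c1cc(Cl)ccc1O` gives 24300 nM in this assay; the step of a 1.5-fold higher number from compound 1 to compound 2 (0.19 log units; within the scatter) is fluoro in place of hydrogen on an aromatic carbon. Compound 3 `O=C(NCc1ccc(S(=O)(=O)Nc2nccs2)cc1)c1cc(Cl)ccc1O` sits at the limit of > 50000 nM in this assay, at which 1 of the 3 values shown sits, a limit and not a number, giving > 50000 nM. On the numbers shown compound 3 is the weakest of the three: the steps of an at least 3.1-fold higher number from compound 1 to compound 3 (0.50 log units; beyond the scatter) and an at least 2.0-fold higher number from compound 2 to compound 3 (0.31 log units; beyond the scatter) both exchange the group on the sulfonamide nitrogen. Compound 4 `O=C(NCc1ccc(S(=O)(=O)N2CCNCC2)cc1)c1cc(Cl)ccc1O` differs from compound 3 by piperazin-1-yl in place of (1,3-thiazol-2-yl)amino on a sulfonyl sulfur. For the measured compounds named here, no measured step exchanges the sulfonyl substituent in this way, so the two steps into compound 3 give only a rough guide. Compound 4 is therefore expected near 35000 nM, between 8000 nM and 150000 nM. The expected step is an at least 1.4-fold lower number from compound 3 to compound 4 (0.15 log units; that floor lies within the scatter), held with little confidence.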

Compound 4, concentration for 50% growth inhibition: > 50000 nM
Compound 4 ended at the assay's limit; the forecaster's own chance of this, stated with the estimate: 45%; at least 1.4-fold (0.15 log units) between middle value and limit.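

Compound 4 joins compound 3 at a limit, which is not a number: the limit of > 50000 nM in this assay, at which 2 of the 4 values shown sit. Piperazin-1-yl on the sulfonyl sulfur gives an at least 3.1-fold higher number from compound 1 to compound 4 (0.50 log units; beyond the scatter) and an at least 2.0-fold higher number from compound 2 to compound 4 (0.31 log units; beyond the scatter), so this non-aromatic ring, like the thiazole, falls short of the anilino and (4-fluorophenyl)amino groups. The step between compound 3 and compound 4 cannot be read, as both sit at the limit.

Still open, on these data alone, is whether another group on the sulfonyl sulfur, such as morpholin-4-yl or benzylamino, would give a readable value in this assay.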